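This account rests on a few compounds, and the source may have more. Where it says the series, first, only, none or still open, it means among the compounds named here.

Of the compounds shown here, two have so far been measured in an assay on isolated protein (strain Sprague-Dawley) for inhibition of Amine oxidase [flavin-containing] B (Rattus norvegicus), read by spectrophotometry, with a stated time of 5 min; a lower number here means a stronger inhibitor, a higher number a weaker inhibitor. Compound 1 `CCOC(=O)COc1cc(=O)oc2cc(OCc3cccc(Cl)c3)ccc12` gives 1820 nM, the higher of the two numbers and therefore the weaker inhibitor. Compound 2 `NC(=O)COc1cc(=O)oc2cc(OCc3cccc(Br)c3)ccc12` gives 8.91 nM, a gap from compound 1 that lies well beyond the usual scatter. The next step alters one group of compound 1: carbamoyl in place of (ethoxycarbonyl)methoxy on an aromatic carbon. This yields compound 3 `NC(=O)c1cc(=O)oc2cc(OCc3cccc(Cl)c3)ccc12`, not yet measured. Compound 2 also carries an amide and reaches 8.91 nM. The expected step is a 15-fold lower number from compound 1 to compound 3 (1.18 log units; beyond the scatter), toward a lower number, hence a stronger inhibitor, beyond the scatter. Compound 3 is estimated at 120 nM, within a range from 10 nM to 1500 nM.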

Compound 3, half-maximal inhibitory concentration: 234 nM
Compound 3: the middle estimate sits 2.0-fold (0.29 log units) below what was measured, and the stated range covers the measured number.
By their numbers in this assay, from the lowest: compound 2; then compound 3; then compound 1.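

Carbamoyl in place of (ethoxycarbonyl)methoxy, on the aromatic carbon opposite the ring oxygen, gives a 7.8-fold lower number from compound 1 to compound 3 (0.89 log units; beyond the scatter) in this assay, so a stronger inhibitor results at this position with a much smaller group carrying an amide hydrogen. No measurement shown gives a reason for this step. The change replaces the whole group at once, so the roles of its size, its ether oxygen and its amide hydrogen cannot be separated. Open, from the compounds shown here alone, is how an ethyl ester placed directly on this carbon, a carboxylic acid or an amine would compare with carbamoyl here.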